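The source may hold more compounds than are shown below. What is called first, only, known or untested is meant among the compounds shown, and "the series" means these compounds.

Measured compounds:
compound 1 `Cc1cccc(-n2cc(-c3cccc(NS(=O)(=O)c4c[nH]c(=O)[nH]c4=O)c3)nn2)c1` — 7050 nM
compound 2 `Cc1ccc(-n2cc(-c3cccc(NS(=O)(=O)c4c[nH]c(=O)[nH]c4=O)c3)nn2)cc1` — > 20000 nM
compound 3 `Cc1cccc(-n2cc(-c3ccc(NS(=O)(=O)c4c[nH]c(=O)[nH]c4=O)cc3)nn2)c1` — > 20000 nM

Three compounds of the series have been run in a functional assay on HepG2 cells (Homo sapiens) for antiproliferative activity, read by MTT assay, with a stated time of 24 h; a lower number here means a stronger inhibitor, a higher number a weaker inhibitor. Compound 1 gives 7050 nM. For compound 2 the result is a limit of the assay, > 20000 nM. For compound 3 the result is likewise a limit, > 20000 nM. For the measured compounds named here, the one counted step is the change (4-methylphenyl in place of 3-methylphenyl on an aromatic nitrogen), which produced an at least 2.8-fold higher number from compound 1 to compound 2 (0.45 log units; beyond the scatter). How the core of compound 1 and the core of compound 3 differ is not broken down here.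

Compound 4 `Cc1ccc(-n2cc(-c3ccc(NS(=O)(=O)c4c[nH]c(=O)[nH]c4=O)cc3)nn2)cc1` has not been measured in this assay. It stands to compound 3 as compound 2 stands to compound 1: the change is 4-methylphenyl in place of 3-methylphenyl on an aromatic nitrogen, the same change at the same place as the measured step. Compound 3 already sits at the limit of > 20000 nM in this assay, at which 2 of the 3 values shown sit, so no number is available for a step to rise from. The expectation for compound 4 is that the result is again a limit, in line with compound 2 at > 20000 nM. For compound 4 the expected step is a step that the limit leaves unreadable from compound 3 to compound 4. The estimated value for compound 4 is 30000 nM, with the range 15000 nM to 80000 nM.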

Compound 4, half-maximal inhibitory concentration: 11600 nM
Estimate against measurement, compound 4: 2.6-fold (0.41 log units) above; measured number below the stated range.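

In this assay, 4-methylphenyl in place of 3-methylphenyl on an aromatic nitrogen gives an at least 1.7-fold lower number from compound 3 to compound 4 (0.23 log units; that floor lies within the scatter). Taken alone, this step is small, but the change does not carry from one core to the other as a fixed step: the same change on two cores in this assay, an at least 2.8-fold higher number (0.45 log units; beyond the scatter) from compound 1 to compound 2 and an at least 1.7-fold lower number (0.23 log units; that floor lies within the scatter) from compound 3 to compound 4, at least 4.8-fold (0.68 log units) apart, beyond the scatter of two such steps. This shows that the outcome of the change depends on the core in these two pairs, but it gives neither the true size of either step nor a rule for any other core, and the steps remain floors: the limit of > 20000 nM in this assay, at which 2 of the 4 values shown sit.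

The compounds shown leave open whether the same dependence on the core appears with other groups on the aromatic nitrogen, such as a plain phenyl, or a phenyl bearing a chlorine, an amine or a carboxylic acid in place of the methyl. They also leave open whether a longer chain, such as ethyl or propyl, in place of the methyl would follow either of the two steps.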